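Replacing the 2,4,6-trifluorophenyl group of compound 3

This account rests on a few compounds, and the source may have more. Where it says the series, first, only, none or still open, it means among the compounds named here.

In a functional assay on HCT-116 cells (Homo sapiens) for inhibition, read by colorimetric assay, with a stated time of 3 days (a higher number here means a weaker inhibitor, a lower number a stronger inhibitor), compound 1 (`COc1ccc(NC(=O)CCCCCCNC(=O)C(O)(O)C(F)(F)F)cc1`) gives 4520 nM, compound 2 (`O=C(CCCCCCNC(=O)C(O)(O)C(F)(F)F)Nc1ccc(F)cc1F`) gives 18500 nM and compound 3 (`O=C(CCCCCCNC(=O)C(O)(O)C(F)(F)F)Nc1c(F)cc(F)cc1F`) gives 22200 nM. Compound 3 thus stands level with compound 2 at the weaker end of this small set, as the added fluoro on an aromatic carbon gives only a 1.2-fold higher number from compound 2 to compound 3 (0.08 log units; within the scatter). The unmeasured compound 4 (`CC(=O)c1ccc(NC(=O)CCCCCCNC(=O)C(O)(O)C(F)(F)F)cc1`) carries 4-acetylphenyl in place of 2,4,6-trifluorophenyl on an amide-type nitrogen. Going by the values given here, no measured compound carries an acetyl group, so the closest guides are the two changes away from 4-methoxyphenyl. Replacing it with 2,4-difluorophenyl gave a 4.1-fold higher number from compound 1 to compound 2 (0.61 log units; beyond the scatter), and replacing it with 2,4,6-trifluorophenyl gave a 4.9-fold higher number from compound 1 to compound 3 (0.69 log units; beyond the scatter). Compound 4 resembles compound 1 in having no fluoro on its aromatic ring, so a modest move toward a stronger inhibitor is expected, recovering part of that loss. The expected change is a 2.8-fold lower number from compound 3 to compound 4 (0.44 log units; beyond the scatter). For compound 4 the estimated value is 8000 nM, with an expected range of 2800 nM to 23000 nM.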

Compound 4, half-maximal inhibitory concentration: 12100 nM
The estimate for compound 4 lay 1.5-fold (0.18 log units) below the measured number; measured number inside the range.
By their numbers in this assay, from the lowest: compound 1; then compounds 4, 2 and 3 (each within the scatter of the next).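

In this assay, a ring without fluoro did not by itself return the number to the level of the 4-methoxyphenyl compound: a 2.7-fold higher number from compound 1 to compound 4 (0.43 log units; beyond the scatter), so the exchange of methoxy for acetyl on an aromatic carbon costs potency in this set. The 4-acetylphenyl group cannot be told apart from either fluorinated group: a 1.8-fold lower number from compound 3 to compound 4 (0.26 log units; within the scatter), and a 1.5-fold lower number from compound 2 to compound 4 (0.18 log units; within the scatter). Among these compounds, then, fluoro on the ring is not needed for the weaker level at this amide-type nitrogen, and only compound 1 stands apart from the other three. Nothing available here accounts for this difference between the groups.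

From the compounds shown here alone, what an unsubstituted phenyl or a 4-aminophenyl group would give on this nitrogen stays open. So does whether the same order of groups would hold with a longer chain.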